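The compounds below may be only part of what the source reports. "The series", "measured", "known", "first", "only" and "open" are said of these compounds alone.

Measured compounds in a functional assay on the whole organism with Mus musculus as the target, in the maximal electroshock model, at a dose of 50 mg/kg by the oral route; a higher number here means more inhibition at the dose given (going by the name of the read-out), a lower number less inhibition:
compound 1, `CN(C)CCCOc1ccccc1/C=C/c1ccccc1`, 14.2%
compound 2, `C(=C/c1ccccc1OCCCCN1CCCC1)\c1ccccc1`, 42.9%
compound 3, `CCCN1CCN(CCCCOc2ccccc2/C=C/c2ccccc2)CC1`, 42.9%

Among the measured compounds shown here, compound 3 stands level with compound 2 at the digits reported, and these two share the highest number of the three; compound 1 lies well beneath them, with a number 28.7 percentage points higher from compound 1 to compound 2 (beyond the scatter) marking the one step in the set that exceeds the scatter. The step from compound 2 to compound 3, in which one cyclic amine replaced another at the same place on the chain, gave no change at the digits printed from compound 2 to compound 3 (within the scatter).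

Compound 4, `NC(=O)C1CCCN(CCCCOc2ccccc2/C=C/c2ccccc2)C1`, has not been measured. It differs from compound 3 as follows: 3-carbamoylpiperidin-1-yl in place of 4-propylpiperazin-1-yl on a saturated chain carbon, four bonds along the chain from an oxygen on an aromatic ring. The step from compound 2 to compound 3 is the one that bears on this change, since it too swapped one cyclic amine for another on the saturated chain carbon four bonds from the aromatic oxygen, and it produced no change beyond the scatter. The step from compound 1 to compound 2 concerned a different place on the chain and is therefore of little guidance here. On this basis compound 4 is expected to remain near compound 3, with a number 2.9 percentage points lower from compound 3 to compound 4 (within the scatter) as the estimated step, not beyond the scatter. The estimated value for compound 4 in this assay is 40%, within a range from 18% to 62%.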

Compound 4, a percentage reported as inhibition, in the whole organism at one dose (the size of the read-out at that dose, not a potency): 0%
Compound 4: the middle estimate sits 40 percentage points above what was measured; measured number outside the range, below it.
By their numbers in this assay, from the lowest: compound 4; then compound 1; then compounds 2 and 3 (each within the scatter of the next).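

In this assay, the group on a saturated chain carbon, four bonds along the chain from an oxygen on an aromatic ring, proved not to be freely exchangeable among cyclic amines: 3-carbamoylpiperidin-1-yl in place of 4-propylpiperazin-1-yl gave a number 42.9 percentage points lower from compound 3 to compound 4 (beyond the scatter), and in place of pyrrolidin-1-yl it gave a number 42.9 percentage points lower from compound 2 to compound 4 (beyond the scatter). The earlier exchange of pyrrolidin-1-yl for 4-propylpiperazin-1-yl at this same place had left the read-out level, so the level shared by compound 2 and compound 3 does not extend to every cyclic amine at this place. Nothing available gives a reason for the drop seen with compound 4.

The compounds shown leave open whether the loss goes with the carbamoyl group or with the piperidine ring itself, which a plain piperidin-1-yl, or a carboxylic acid or nitrile in place of the carbamoyl group, would help to separate. They also leave open whether a morpholine at this place would stay with compound 2 and compound 3 or fall with compound 4.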